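Thiomorpholine to Morpholine: Predicting a Second Swap

The source may hold more compounds than are shown below. What is called first, only, known or untested is meant among the compounds shown, and "the series" means these compounds.

In a functional assay on MCF7 cells (Homo sapiens) for cytotoxicity, read by MTT assay, with a stated time of 72 h, tested at 10 uM (on this read-out higher numbers stand for more inhibition of growth at the one concentration tested and lower numbers for less inhibition of growth), compound 3 `Cc1ccnc(/C(N)=N/NC(=S)N2CCSCC2)c1` gives 62.5%, while compound 1 `Cc1ccnc(/C(N)=N/NC(=S)N2CCOCC2)c1` gives 6.86%. Going by the values given here, the only change between them is morpholin-4-yl in place of thiomorpholin-4-yl on a thiocarbonyl carbon, and it made the step of a number 55.6 percentage points lower from compound 3 to compound 1 (beyond the scatter). Compound 2 `Cc1cccc(/C(N)=N/NC(=S)N2CCSCC2)n1` has the same atoms as compound 3 joined differently, and the difference between the two cores is not broken down here. In this assay compound 2 gives 22.5%. Compound 4 `Cc1cccc(/C(N)=N/NC(=S)N2CCOCC2)n1` awaits measurement and differs from compound 2 by morpholin-4-yl in place of thiomorpholin-4-yl on a thiocarbonyl carbon, the same change at a place described in identical words. Because a number 55.6 percentage points lower from compound 3 to compound 1 (beyond the scatter) was a large drop, compound 2 is expected to lose most of its already modest inhibition, a step estimated at a number 18.5 percentage points lower from compound 2 to compound 4 (beyond the scatter). Compound 4 is therefore estimated at 4%, probably between -8% and 16%.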

Compound 4, percent growth inhibition at one concentration: 39.1%
Compound 4: middle estimate off by 35.1 percentage points, on the low side; measured number outside the range, above it.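

In this assay, morpholin-4-yl in place of thiomorpholin-4-yl on a thiocarbonyl carbon gave a number 16.6 percentage points higher from compound 2 to compound 4 (beyond the scatter), so the effect seen on the first core did not carry over to the second. The two steps point in opposite directions: the same change on two cores in this assay, a number 55.6 percentage points lower (beyond the scatter) from compound 3 to compound 1 and a number 16.6 percentage points higher (beyond the scatter) from compound 2 to compound 4, 72.2 percentage points apart, beyond the scatter of two such steps. This shows that, for these two pairs, the outcome of the change depends on the core it is made on, but it does not show why the direction reverses or what the change would do on any further core.

The compounds shown leave open how a piperidin-1-yl or 4-methylpiperazin-1-yl group at the same place would behave on either core. They also leave open whether these differences would hold at other concentrations.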